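A small side-chain swap on a shared core

The source may hold more compounds than are shown below. What is called first, only, known or untested is meant among the compounds shown, and "the series" means these compounds.

For the measured compounds named here, in an ADME assay on the whole organism (plasma, strain F344/DuCrlCrlj) for pharmacokinetics, with Rattus norvegicus as the target, read by LC-MS, at a dose of 1 mg/kg by the oral route (on this read-out higher numbers stand for higher exposure at the dose given and lower numbers for lower exposure), compound 2 `COc1ccc2nc(COc3ccc(CC(C(N)=O)[S+](C)[O-])cc3)n(C)c2c1` gives 33.9 ng.h/mL as the highest of three numbers so far, with compound 1 `COc1ccc2nc(COc3ccc(CC4(O)SC(=O)NC4=O)cc3)n(C)c2c1` at 11.4 ng.h/mL and compound 3 `COc1ccc2nc(COc3ccc(CC4SC(=O)NC4=O)cc3)[nH]c2c1` at 9.59 ng.h/mL on the lower side. Compound 4 `COc1ccc2nc(COc3ccc(CC(C(N)=O)S(C)(=O)=O)cc3)n(C)c2c1` differs from compound 2 in one place, with a group of 4 heavy atoms (1 carbon, 2 oxygen, 1 sulfur; no ring) in place of a group of 3 heavy atoms (1 carbon, 1 oxygen, 1 sulfur; no ring), on a saturated chain carbon bound to a carbonyl carbon and a saturated chain carbon as the whole change. Going by the values given here, only one measured step bears on this, namely a 3.0-fold higher number from compound 1 to compound 2 (0.47 log units; beyond the scatter) for a different swap that removed a ring, so it says little here. Among the compounds with values here, no measured step shows this swap itself, so no step beyond the scatter is expected, and a 1.1-fold higher number from compound 2 to compound 4 (0.03 log units; within the scatter) is the estimated step in this assay for this change. Compound 4 is expected at 36 ng.h/mL with an estimated range from 12 ng.h/mL to 105 ng.h/mL for now.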

Compound 4, area under the concentration-time curve: 9.85 ng.h/mL
Beside the measured number, compound 4's estimate is 3.7-fold (0.56 log units) above it, and the stated range ends above it.
By their numbers in this assay, from the lowest: compounds 3, 4 and 1 (each within the scatter of the next); then compound 2.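

At this place on a saturated chain carbon, methylsulfonyl in place of the group in compound 2 gives a 3.4-fold lower number from compound 2 to compound 4 (0.54 log units; beyond the scatter) in this assay, so even a small change here can shift exposure beyond the scatter. The open-chain methylsulfonyl group also gives a 1.2-fold lower number from compound 1 to compound 4 (0.06 log units; within the scatter), so losing the ring does not by itself bring a higher number. Nothing at hand gives a reason for the drop. The compounds shown leave open how a carboxylic acid or an amine at this place would compare with compound 2.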